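The source may report more compounds than this note shows. Statements on the series, on what has been measured and on what is new or still open speak of the compounds shown alone.

Measured so far:
Compound 1 `CS(=O)(=O)c1ccc(Nc2nccc(Nc3nc4ccc(Cl)cc4s3)n2)cc1` gives 1400 nM in a functional assay on HeLa cells (Homo sapiens) for antiproliferative activity, read by MTT assay, with a stated time of 48 h; on this read-out higher numbers stand for weaker inhibition and lower numbers for stronger inhibition.
Compound 2 `Cc1cnc(Nc2ccc(S(C)(=O)=O)cc2)nc1Nc1nc2ccc(Cl)cc2s1` gives 4180 nM in this assay.
Compound 3 `COc1ccc(Nc2ncc(C)c(Nc3nc4ccccc4s3)n2)cc1` reaches only a limit, > 50000 nM, in this assay; this is the limit of > 50000 nM in this assay, at which 1 of the 3 values shown sits, and not a number.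

Compound 1 holds the lowest of the two numbers; its nearest neighbour is compound 2, reached by methyl in place of hydrogen on an aromatic carbon, a step of a 3.0-fold higher number from compound 1 to compound 2 (0.48 log units; beyond the scatter). Compound 4 `CS(=O)(=O)c1ccc(Nc2nccc(Nc3nc4ccc(F)cc4s3)n2)cc1` differs from compound 1 by fluoro in place of chloro on an aromatic carbon. Within the data shown here, no measured step exchanges one halogen for another, so the single methyl-for-hydrogen step offers only a rough scale; the observer therefore expects a step of a 1.4-fold higher number from compound 1 to compound 4 (0.15 log units; within the scatter) in this assay, small and probably within the scatter. The estimate for compound 4 is 2000 nM, between 700 nM and 6000 nM.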

Compound 4, half-maximal inhibitory concentration: 560 nM
Estimate against measurement, compound 4: 3.6-fold (0.55 log units) above; measured number below the stated range.
By their numbers in this assay, from the lowest: compound 4; then compound 1; then compound 2. At a limit, above all of these: compound 3.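

In this assay, fluoro in place of chloro on the aromatic carbon gives a 2.5-fold lower number from compound 1 to compound 4 (0.40 log units; beyond the scatter). The only earlier step, methyl in place of hydrogen, raised the number, so this is the first single change shown that moves toward stronger inhibition, and it shows that the halogen at this position affects the read-out. Nothing in hand accounts for this step. Going by these compounds, it remains open how bromo, methoxy or a nitrile would fare at this position. On these data alone, whether the same exchange would lower the number in compound 2 is also open.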